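Moving a Methyl Around the Ring: Expected Cytotoxicity

The compounds below may be only part of what the source reports. "The series", "measured", "known", "first", "only" and "open" are said of these compounds alone.

Measured compounds:
- Compound 1 `O=c1[nH]cc(S(=O)(=O)Nc2cccc(-c3cn(-c4cccc(Cl)c4)nn3)c2)c(=O)[nH]1`: 8330 nM
- Compound 2 `Cc1ccccc1-n1cc(-c2ccc(NS(=O)(=O)c3c[nH]c(=O)[nH]c3=O)cc2)nn1`: "not toxic" (no number reported)

In an ADME assay on L02 cells (Homo sapiens) for cytotoxicity, read by MTT assay, with a stated time of 24 h (a lower number here means that less compound is tolerated, a higher number that more compound is tolerated), compound 1 gives 8330 nM. Compound 2 was reported in this assay only as "not toxic" (no number reported), so no single number marks where it stands; all that is known is that it was tolerated without a measured half-maximal cytotoxic concentration.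

Compound 3 `Cc1ccc(-n2cc(-c3ccc(NS(=O)(=O)c4c[nH]c(=O)[nH]c4=O)cc3)nn2)cc1` has not yet been measured. It differs from compound 2 in one place: 4-methylphenyl in place of 2-methylphenyl on an aromatic nitrogen. Within the data shown here, no step between two measured compounds exists for this kind of change, so its size cannot be read from the data. With compound 2 showing no toxicity, a step of no more than the usual scatter is expected, in no clear direction. Compound 3 is therefore expected to give 30000 nM, within a range from 8000 nM to 150000 nM, and it may well again return no number.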

Compound 3, half-maximal cytotoxic concentration: "not toxic" (no number reported)
For compound 3 the study gives words and no number, and the estimate cannot be compared.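

In this assay compound 2 and compound 3 are both reported in words alone, so no step can be read between 2-methylphenyl and 4-methylphenyl. No evidence shown bears on this result.
The compounds shown leave open whether moving the methyl changes tolerated concentration by any measurable amount.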